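Ester variation in a Rho-associated kinase 2 inhibitor series

The compounds below may be only part of what the source reports. "The series", "measured", "known", "first", "only" and "open" are said of these compounds alone.

Measured compounds, in an assay on isolated protein for inhibition of Rho-associated protein kinase 2 (Homo sapiens), read by radiometric assay; a lower number here means a stronger inhibitor, a higher number a weaker inhibitor:
compound 1, `NCc1ccc(C(=O)Nc2ccncc2F)cc1-c1cccc(C(=O)Oc2ccccc2)c1`: 6.2 nM
compound 2, `NCc1ccc(C(=O)Nc2ccncc2F)cc1-c1cccc(C(=O)OCC2CCCO2)c1`: 2.5 nM
compound 3, `NCc1ccc(C(=O)Nc2ccncc2F)cc1-c1cccc(C(=O)OCC2CCCC2)c1`: 13 nM

All three share one core and differ only in the group on the oxygen next to the carbonyl group. Compound 3 carries the highest number of the three: a 2.1-fold higher number from compound 1 to compound 3 (0.32 log units; beyond the scatter) and a 5.2-fold higher number from compound 2 to compound 3 (0.72 log units; beyond the scatter), both beyond the scatter, while a 2.5-fold lower number from compound 1 to compound 2 (0.39 log units; beyond the scatter) marks the other modest step in the set.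

The next compound is compound 4, `NCc1ccc(C(=O)Nc2ccncc2F)cc1-c1cccc(C(=O)OCC2CC2)c1`. Relative to compound 3 the change is cyclopropyl in place of cyclopentyl on a saturated chain carbon bound to an oxygen next to a carbonyl group.

Within the data shown here, the steps that bear on this are the two that change the same position: a 5.2-fold higher number from compound 2 to compound 3 (0.72 log units; beyond the scatter) and a 2.1-fold higher number from compound 1 to compound 3 (0.32 log units; beyond the scatter). Among the measured compounds shown here, each is modest, and none of the measured steps swaps one carbocycle for a smaller one, so there is no direct precedent for the direction. Given that all variation at this position so far stays within a modest span, a modest step from compound 3 to compound 4 in this assay is expected, a 1.4-fold lower number from compound 3 to compound 4 (0.16 log units; within the scatter), with the direction uncertain and a lower number slightly favoured. For compound 4 the estimate in this assay is 9 nM, within a range of 3 nM to 27 nM.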

Compound 4, half-maximal inhibitory concentration: 2.7 nM
Beside the measured number, compound 4's estimate is 3.3-fold (0.52 log units) above it; the measured number lies below the stated range.
By their numbers in this assay, from the lowest: compounds 2 and 4 (each within the scatter of the next); then compound 1; then compound 3.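

In this assay, among these compounds, the cyclopropyl for cyclopentyl swap on a saturated chain carbon bound to an oxygen next to a carbonyl group is the first comparison of two carbocycles at this position, and ring size matters here: a 4.8-fold lower number from compound 3 to compound 4 (0.68 log units; beyond the scatter). A ring oxygen is not needed to reach the low end of the set, since a 1.1-fold higher number from compound 2 to compound 4 (0.03 log units; within the scatter), which leaves oxolan-2-yl and cyclopropyl indistinguishable and means the earlier gap between compound 2 and compound 3 cannot be assigned to the ring oxygen alone. Cyclopropylmethyl also improves on phenyl, with a 2.3-fold lower number from compound 1 to compound 4 (0.36 log units; beyond the scatter), so compound 3 now stands alone as the weakest of the four, its steps to all the others lying beyond the scatter.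

Nothing available accounts for why the smaller carbocycle gives the lower number. Two carbocycles give one step rather than a trend, so the compounds shown leave open where cyclobutylmethyl or cyclohexylmethyl would fall, and whether an open chain such as isobutyl would track with cyclopropylmethyl or with cyclopentylmethyl.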